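The source may report more compounds than this note shows. Statements on the series, on what has been measured and on what is new or still open speak of the compounds shown alone.

Compound 1 `CCCc1ccc(N2C(=O)NC3(CSC4=C3C(=O)c3ncccc3C4=O)C2=O)cc1` is the point of departure. In a functional assay on SF-268 cells (Homo sapiens) for antiproliferative activity, read by MTT assay, with a stated time of 96 h (a lower number here means a stronger inhibitor, a higher number a weaker inhibitor), compound 1 gives 300 nM, the lowest of the three numbers measured. Compound 3 `CCc1ccc(N2C(=O)NC3(CSC4=C3C(=O)c3ncccc3C4=O)C2=O)cc1` gives 450 nM in this assay, and compound 2 `COc1ccc(N2C(=O)NC3(CSC4=C3C(=O)c3ncccc3C4=O)C2=O)cc1` gives 650 nM. The step of a 1.5-fold higher number from compound 1 to compound 3 (0.18 log units; within the scatter) sits inside the usual scatter, so compounds 1 and 3 cannot be told apart on these numbers; the step of a 2.2-fold higher number from compound 1 to compound 2 (0.34 log units; beyond the scatter) is modest but lies beyond it.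

Compound 4 `CC(C)(C)c1ccc(N2C(=O)NC3(CSC4=C3C(=O)c3ncccc3C4=O)C2=O)cc1` carries the change (tert-butyl in place of propyl on an aromatic carbon). Among the measured compounds shown here, no measured step reproduces this change. The nearest guidance comes from the alkyl pair: lengthening ethyl to propyl, read through a 1.5-fold higher number from compound 1 to compound 3 (0.18 log units; within the scatter), moved the number by less than the scatter, which suggests that this assay is not very sensitive to the size of an alkyl group on that aromatic carbon. For the measured compounds named here, the only step beyond the scatter, a 2.2-fold higher number from compound 1 to compound 2 (0.34 log units; beyond the scatter), exchanged an alkyl group for methoxy, which is not what happens here.

On that basis compound 4 is expected to land close to compound 1, with the step of a 1.2-fold higher number from compound 1 to compound 4 (0.07 log units; within the scatter) estimated to stay within the scatter. The estimate for compound 4 in this assay is 350 nM, with a range from 150 nM to 800 nM.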

Compound 4, half-maximal inhibitory concentration: 500 nM
Estimate against measurement, compound 4: 1.4-fold (0.15 log units) below; low and high end bracket the measured number.
By their numbers in this assay, from the lowest: compounds 1, 3, 4 and 2 (each within the scatter of the next, the first and the last beyond it).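

In this assay, the step of a 1.7-fold higher number from compound 1 to compound 4 (0.22 log units; within the scatter) stays within the scatter, so a branched tert-butyl group on this aromatic carbon, para to a large group, cannot be told apart from the straight propyl group. The step of a 1.1-fold higher number from compound 3 to compound 4 (0.05 log units; within the scatter) also stays within the scatter, so among compounds 1, 3 and 4, neither chain length nor branching of the alkyl group gives a measurable difference here. The step of a 1.3-fold lower number from compound 2 to compound 4 (0.11 log units; within the scatter) is within the scatter too, so compound 4 cannot be separated from the methoxy compound 2 either, even though compound 1 can, and the step from compound 1 to compound 2 remains the only one beyond the scatter; nothing available bears on the reason for these numbers.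

The compounds shown leave open whether anything at this position would move the number well beyond the scatter, since they carry only three alkyl groups and a methoxy group. A longer chain such as octyl, an amine or a carboxylic acid on the same aromatic carbon would test whether this tolerance extends past those groups.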